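Adding a Chloro Group to a Triazine Modulator

A few compounds are considered here, and "the series" means these few. Any claim that something is new, unique, unknown or untested is made for them only; others in the source may bear on it.

Measured so far:
compound 1 `Nc1nc(NCc2ccccc2)nc(-c2cc(Cl)ccc2CO)n1` gives 4.49
compound 2 `Nc1nc(NCCCc2ccccc2)nc(-c2ccccc2CO)n1` gives 5.22

Compound 2 stands highest of the two numbers measured in a functional assay on cells for positive allosteric modulation of G-protein coupled receptor 68 (Homo sapiens), read by a luciferase reporter and cAMP accumulation, with a stated time of 30 min, at pH 6.8 and pH 8.3, in the presence of a further agent that is not named here; on this read-out higher numbers stand for higher potency (the scale is a negative logarithm) and lower numbers for lower potency; compound 1 lies well below it, beyond the usual scatter. The two differ in more than one place, so their gap cannot be tied to a single change. Compound 3 `Nc1nc(NCCCc2ccccc2)nc(-c2cc(Cl)ccc2CO)n1` differs from compound 2 by one change only: chloro in place of hydrogen on an aromatic carbon. Going by the values given here, no single-point step of this kind has been measured here, so only a small step, in either direction or none beyond the scatter, is expected in this assay, as a number 0.08 log units higher from compound 2 to compound 3 (within the scatter). Compound 3 is expected to give 5.3, within 4.7 to 5.9.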

Compound 3, negative logarithm of the antagonist equilibrium constant: 5.35
Beside the measured number, compound 3's estimate is 0.05 log units below it; measured number inside the range.
By their numbers in this assay, from the lowest: compound 1; then compounds 2 and 3 (each within the scatter of the next).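

In this assay, chloro in place of hydrogen on the aromatic carbon para to the hydroxymethyl group gives a number 0.13 log units higher from compound 2 to compound 3 (within the scatter), so this position accepts chloro without a change beyond the scatter. With chloro held constant, phenethyl in place of phenyl on the saturated chain carbon gives a number 0.86 log units higher from compound 1 to compound 3 (beyond the scatter), which ties a gap beyond the scatter to one change in the chain. Nothing here explains either step.

As far as these compounds go, whether bromo or methoxy at the chloro position would shift the number remains open. So does the effect of a longer chain than phenethyl.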